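Aryl replacement on the ethoxy chain and microsomal half-life

A few compounds are considered here, and "the series" means these few. Any claim that something is new, unique, unknown or untested is made for them only; others in the source may bear on it.

In an ADME assay on microsomes from liver (Homo sapiens) for metabolic stability, read by LC-MS, tested at 0.5 uM (on this read-out lower numbers stand for a shorter-lived compound and higher numbers for a longer-lived compound), compound 1, `COc1ccc(CCOc2ccc(-c3c(C)nc(C)c([C@H](OC(C)(C)C)C(=O)O)c3N3CCC(C)(C)CC3)cc2)cc1`, reaches only the limit of the read-out, > 2 h. Compound 2, `Cc1ccc(CCOc2ccc(-c3c(C)nc(C)c([C@H](OC(C)(C)C)C(=O)O)c3N3CCC(C)(C)CC3)cc2)s1`, also stops at a limit, > 2 h. Compound 3, `Cc1nc(C)c([C@H](OC(C)(C)C)C(=O)O)c(N2CCC(C)(C)CC2)c1-c1ccc(OCCc2cccnc2)cc1`, gives a number, 0.367 h. The step to compound 4, `Cc1nc(CCOc2ccc(-c3c(C)nc(C)c([C@H](OC(C)(C)C)C(=O)O)c3N3CCC(C)(C)CC3)cc2)cs1`, is 2-methyl-1,3-thiazol-4-yl in place of 4-methoxyphenyl on a saturated chain carbon, two bonds along the chain from an oxygen on an aromatic ring. The measured steps that bear on it are a step that the two limits leave unreadable from compound 1 to compound 2 and an at least 5.4-fold lower number from compound 1 to compound 3 (0.73 log units; beyond the scatter); since the limit of > 2 h in this assay, at which 2 of the 3 values shown sit, holds two of the three values, the thiophene step cannot be sized. The entering group resembles the 5-methylthiophen-2-yl of compound 2 in its sulfur-containing five-membered ring and the pyridin-3-yl of compound 3 in carrying a ring nitrogen, so a drop is expected, smaller than an at least 5.4-fold lower number from compound 2 to compound 3 (0.73 log units; beyond the scatter). Compound 4 is estimated at 1 h, between 0.3 h and 2.5 h, an expected step of an at least 2.0-fold lower number from compound 1 to compound 4 (0.30 log units; that floor lies within the scatter).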

Compound 4, half-life: 0.683 h
The estimate for compound 4 lay 1.5-fold (0.17 log units) above the measured number; the range from low to high includes it.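

In this assay, a sulfur-containing five-membered ring does not by itself keep the half-life at the limit of the read-out: the 2-methyl-1,3-thiazol-4-yl group gives an at least 2.9-fold lower number from compound 1 to compound 4 (0.46 log units; beyond the scatter) and an at least 2.9-fold lower number from compound 2 to compound 4 (0.46 log units; beyond the scatter). Both groups carrying a ring nitrogen fall short of that limit, yet they are not separated, with a 1.9-fold higher number from compound 3 to compound 4 (0.27 log units; within the scatter).

Going by these compounds, the step from compound 1 to compound 2 cannot be read, and the two drops to compound 4 are known only as floors: the limit of > 2 h in this assay, at which 2 of the 4 values shown sit. Whether a 2-methyl-1,3-oxazol-4-yl group would behave like the thiazole remains open.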